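This account rests on a few compounds, and the source may have more. Where it says the series, first, only, none or still open, it means among the compounds named here.

Measured compounds:
- compound 1 `CNC(=O)c1c(O)c2cccnc2n(-c2ccccc2)c1=O`: 21%
- compound 2 `O=C(NN1CCOCC1)c1c(O)c2cccnc2n(-c2ccccc2)c1=O`: -26.2%
- compound 3 `O=C(Nc1ccc(Cl)cc1)c1c(O)c2cccnc2n(-c2ccccc2)c1=O`: 2.5%

All three share one core and differ only in the group carried on the amide-type nitrogen. In a functional assay on the whole organism for inhibition, with Rattus norvegicus as the target, read by cytopathic effect and paw edema, at a dose of 100 mg/kg by the oral route (on this read-out lower numbers stand for less inhibition and higher numbers for more inhibition at the one dose given (going by the name of the read-out)), compound 1 stands highest of the three numbers. Compound 3 is nearest, reached by the step of a number 18.5 percentage points lower from compound 1 to compound 3 (beyond the scatter), and compound 2 is furthest, reached by the step of a number 47.2 percentage points lower from compound 1 to compound 2 (beyond the scatter); both steps lie beyond the scatter, so the methyl-bearing compound 1 gives the highest number of the measured set.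

Compound 4 `Cc1cccc(NC(=O)c2c(O)c3cccnc3n(-c3ccccc3)c2=O)c1` has not yet been measured. It differs from compound 1 in the change (3-methylphenyl in place of methyl on an amide-type nitrogen). Going by the values given here, the measured step that bears most directly on it is the one from compound 1 to compound 3, where an aromatic ring also took the place of methyl on the amide-type nitrogen and the number fell modestly. The step to compound 2 is a larger drop, but morpholin-4-yl is not an aromatic ring and so speaks less directly to a 3-methylphenyl group. On this basis a modest fall in this assay is expected for compound 4, in the same direction as compound 3 showed, giving the expected step of a number 15 percentage points lower from compound 1 to compound 4 (beyond the scatter). The estimated value for compound 4 is 6%, within the range -14% to 26%.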

Compound 4, a percentage reported as inhibition, in the whole organism at one dose (the size of the read-out at that dose, not a potency): 4.5%
Estimate against measurement, compound 4: 1.5 percentage points above, and the stated range covers the measured number.
By their numbers in this assay, from the lowest: compound 2; then compounds 3 and 4 (each within the scatter of the next); then compound 1.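

In this assay a second aromatic ring on the amide-type nitrogen also gives a lower number than methyl, with a number 16.5 percentage points lower from compound 1 to compound 4 (beyond the scatter), so the fall seen earlier is not tied to 4-chlorophenyl alone, and all three larger groups measured here sit below methyl. The ring's substituent makes no readable difference in this pair, since a number 2 percentage points higher from compound 3 to compound 4 (within the scatter), so 3-methylphenyl and 4-chlorophenyl cannot be told apart at this one dose. Compound 4 also stands clear of the morpholine-bearing compound, with a number 30.7 percentage points higher from compound 2 to compound 4 (beyond the scatter), which shows again that the nature of the group on this nitrogen matters and that a larger group does not always give the same result.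

No measurement available here explains why these groups give these numbers. Going by these compounds, it remains open whether a plain phenyl, a benzyl group, or a short alkyl chain such as ethyl or butyl on this nitrogen would keep the number near that of compound 1, fall to that of compound 4, or rise above both.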